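The compounds below may be only part of what the source reports. "The series", "measured", "known", "first", "only" and "open" are said of these compounds alone.

Measured compounds in an assay on cell membranes for displacement of a labelled ligand from metabotropic glutamate receptor 5 (Rattus norvegicus), tested at 1 uM; on this read-out lower numbers stand for less inhibition and higher numbers for more inhibition at the one concentration tested (going by the name of the read-out):
- compound 1 `O=C(CCc1ccc(F)cc1)c1[nH]c2ccccc2c1-c1ccc(F)cc1`: 4%
- compound 2 `Fc1ccc(-c2nnc(-c3sc4ncccc4c3-c3ccc(Cl)cc3)o2)cc1`: 24%
- compound 3 `O=C(c1ccc(Cl)cc1)c1sc2ncccc2c1-c1ccc(F)cc1`: 30%

Compound 3 gives the highest number of the three in this assay. Its nearest neighbour on this read-out is compound 2, whose value lies within the usual scatter of compound 3, so the two cannot be told apart. Compound 1 lies well beyond the scatter below compound 3, and that gap is the only separation among the three that can be taken as real. Within the data shown here, no single-change step between measured compounds is available in this set, so nothing about the effect of any one substitution is known from measurement.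

The next compound, compound 4 `CN(C(=O)c1sc2ncccc2c1-c1ccc(F)cc1)c1ccc(F)cc1`, differs from compound 3 in one place: (4-fluorophenyl)(methyl)amino in place of 4-chlorophenyl on a carbonyl carbon. Among the measured compounds shown here, with no measured step of this kind to lean on, the expectation is for a step from compound 3 to compound 4 of about the size of the scatter, if any, with the direction uncertain, given as a number 8 percentage points lower from compound 3 to compound 4 (within the scatter). On that basis compound 4 is expected to give 22% in this assay, with a range from 2% to 45%.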

Compound 4, a percentage reported as inhibition, at one concentration (the size of the read-out at that concentration, not a potency): 19%
Compound 4: the middle estimate sits 3 percentage points above what was measured; low and high end bracket the measured number.
By their numbers in this assay, from the lowest: compound 1; then compounds 4, 2 and 3 (each within the scatter of the next, the first and the last beyond it).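

In this assay, among these compounds, the change on this carbonyl carbon gives the first single-change step: a number 11 percentage points lower from compound 3 to compound 4 (beyond the scatter), with (4-fluorophenyl)(methyl)amino in place of 4-chlorophenyl. Among the compounds shown here, the group on the carbonyl carbon therefore affects this read-out, which the earlier compounds could not show, although the size of the effect is modest and its direction is known only for this one replacement. The step bundles several differences, namely a nitrogen and a methyl that enter and a fluorine that takes the place of a chlorine, and no measurement available here offers an explanation for it.

From the compounds shown here alone, it remains open which of these differences carries the step: 4-fluorophenyl directly on the carbonyl carbon would isolate the halogen, and the same amide with a hydrogen in place of the methyl would isolate the methyl. Also open, going by these compounds, is how this position responds to quite different groups, such as a simple alkyl amine or a carboxylic acid, and whether any such change would raise the number rather than lower it.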